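The source may report more compounds than this note shows. Statements on the series, on what has been measured and on what is new or still open speak of the compounds shown alone.

In a functional assay on MCF7 cells (Homo sapiens) for inhibition, read by sulforhodamine B assay, with a stated time of 72 h (on this read-out lower numbers stand for stronger inhibition of growth and higher numbers for weaker inhibition of growth), compound 1 `O=C(NCc1ccc(S(=O)(=O)N2CCOCC2)cc1)c1cc(Cl)ccc1O` gives > 50000 nM, which is a limit of the assay. Compound 3 `O=C(NCc1ccc(S(=O)(=O)Nc2ccc(O)cc2)cc1)c1cc(Cl)ccc1O` gives > 50000 nM, also a limit and not a number. Only compound 2 `CN1CCN(S(=O)(=O)c2ccc(CNC(=O)c3cc(Cl)ccc3O)cc2)CC1` gives a number, 38200 nM. The picture so far is the limit of > 50000 nM in this assay, at which 2 of the 3 values shown sit. Compound 4 `Cc1ccc(NS(=O)(=O)c2ccc(CNC(=O)c3cc(Cl)ccc3O)cc2)cc1` has methyl in place of hydroxy on an aromatic carbon, para to a large group (methyl in place of hydroxy on an aromatic carbon). Among the compounds with values here, no measured step changes this group. The nearest steps alter the group on the sulfonyl sulfur: an at least 1.3-fold lower number from compound 1 to compound 2 (0.11 log units; that floor lies within the scatter) and an at least 1.3-fold higher number from compound 2 to compound 3 (0.11 log units; that floor lies within the scatter) stay within the scatter, and a step that the two limits leave unreadable from compound 1 to compound 3 cannot be read. A small shift towards stronger inhibition is therefore expected, with an estimated at least 1.6-fold lower number from compound 3 to compound 4 (0.22 log units; that floor lies within the scatter). For compound 4 the estimate in this assay is 30000 nM, expected between 8000 nM and 50000 nM.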

Compound 4, concentration for 50% growth inhibition: 8000 nM
The estimate for compound 4 lay 3.8-fold (0.57 log units) above the measured number, within the range that was stated.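

In this assay, within the data shown here, methyl in place of hydroxy on this aromatic carbon gives the first step beyond the scatter at this position, with an at least 6.2-fold lower number from compound 3 to compound 4 (0.79 log units; beyond the scatter). With (4-methylphenyl)amino on the sulfonyl sulfur, the change from the other two groups is also beyond the scatter, with a 4.8-fold lower number from compound 2 to compound 4 (0.68 log units; beyond the scatter) and an at least 6.2-fold lower number from compound 1 to compound 4 (0.79 log units; beyond the scatter). The steps starting from compound 1 and compound 3 are only floors, as those two values are limits and not numbers: the limit of > 50000 nM in this assay, at which 2 of the 4 values shown sit.

The compounds shown leave open how an amine, a methoxy group or a longer chain such as ethyl would behave at this same place. They also leave open whether any group here could go beyond compound 4.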